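The source may hold more compounds than are shown below. What is called first, only, known or untested is meant among the compounds shown, and "the series" means these compounds.

Measured in a functional assay on NCI-H460 cells (Homo sapiens) for antiproliferative activity, read by MTT assay, with a stated time of 48 h; on this read-out lower numbers stand for stronger inhibition and higher numbers for weaker inhibition:

- compound 1 `CCCCC1(O)C(=O)Nc2ccc(Nc3ccc(C)cc3)cc21`: 31800 nM
- compound 2 `CCCCC1(O)C(=O)Nc2ccc(Nc3ccc(F)cc3)cc21`: 32500 nM
- compound 3 `CCCCC1(O)C(=O)Nc2ccc(Nc3ccc(Cl)cc3)cc21`: 24400 nM

Compound 3, at 24400 nM, cannot be separated from the other two compounds, since its value lies within the scatter of both. The next compound to be tested, compound 4 `CCCCC1(O)C(=O)Nc2ccc(Nc3ccc(C(F)(F)F)cc3)cc21`, has trifluoromethyl in place of chloro on an aromatic carbon.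

Among the compounds with values here, three measured steps bear on this change, and each swaps one group at that same place: a 1.0-fold higher number from compound 1 to compound 2 (0.01 log units; within the scatter), a 1.3-fold lower number from compound 1 to compound 3 (0.12 log units; within the scatter) and a 1.3-fold lower number from compound 2 to compound 3 (0.12 log units; within the scatter). All three are small and within the scatter. Within the data shown here, no measured compound carries trifluoromethyl, and it is larger than the groups tried so far, so the forecast remains uncertain. Even so, these steps give no reason to expect a change beyond the scatter in this assay, in either direction.

The expected result is a 1.1-fold higher number from compound 3 to compound 4 (0.04 log units; within the scatter). Compound 4 is estimated at 27000 nM, with an expected range of 14000 nM to 52000 nM.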

Compound 4, half-maximal inhibitory concentration: 12000 nM
Compound 4: middle estimate off by 2.3-fold (0.35 log units), on the high side; the measured number lies below the stated range.
By their numbers in this assay, from the lowest: compound 4; then compounds 3, 1 and 2 (each within the scatter of the next).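

In this assay, methyl, fluoro and chloro had given no step beyond the scatter at this position, so the position could have seemed indifferent to the group placed there. Trifluoromethyl is the first group to separate from the others, with a 2.0-fold lower number from compound 3 to compound 4 (0.31 log units; beyond the scatter) and a 2.7-fold lower number from compound 2 to compound 4 (0.43 log units; beyond the scatter) and a 2.7-fold lower number from compound 1 to compound 4 (0.42 log units; beyond the scatter), so compound 4 has the lowest number of the four, though each step is modest. Nothing measured here accounts for this shift.

From the compounds shown here alone, it remains open whether other groups at this position, such as a nitrile, a methoxy group or an amine, would lower the number further or leave it among the first three compounds. Going by these compounds, it is also open whether the step from chloro to trifluoromethyl would hold if the chain on the shared core were shorter or longer.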